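This account rests on a few compounds, and the source may have more. Where it says the series, first, only, none or still open, it means among the compounds named here.

Measured so far in a functional assay on HCT-116 cells (Homo sapiens), read by MTT assay, with a stated time of 72 h; on this read-out higher numbers stand for weaker inhibition and lower numbers for stronger inhibition:
- compound 1, `COc1ncnc2c1c(-c1ccoc1)cn2[C@@H]1O[C@H](CO)[C@@H](O)[C@H]1O`: in this assay compound 1 gives 130 nM.
- compound 2, `O=c1[nH]cnc2c1c(-c1ccco1)cn2[C@@H]1O[C@H](CO)[C@@H](O)[C@H]1O`: in this assay compound 2 gives only a limit, > 20000 nM.
- compound 3, `Cc1nc(N)c2c(-c3cccs3)cn([C@@H]3O[C@H](CO)[C@@H](O)[C@H]3O)c2n1`: in this assay compound 3 gives only a limit, > 20000 nM.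

Compound 3 therefore stands at the limit of this assay rather than at a number, and compound 2 stands at the same limit; only compound 1 gives a measured value, and that value lies on a different core. Within the data shown here, no step between two measured compounds that differ in one place is available, so nothing measures the effect of changing the aromatic group alone. the limit of > 20000 nM in this assay, at which 2 of the 3 values shown sit, marks where compound 3 sits.

Compound 4, `Cc1nc(N)c2c(-c3ccoc3)cn([C@@H]3O[C@H](CO)[C@@H](O)[C@H]3O)c2n1`, is the next compound to be measured in this assay. furan-3-yl in place of thiophen-2-yl on an aromatic carbon

Since compound 3 is known only as a limit, any step can be stated only as an expectation. Compound 4 is expected to remain weak, near 15000 nM, within 3000 nM to 40000 nM. The step of an at least 1.3-fold lower number from compound 3 to compound 4 (0.12 log units; that floor lies within the scatter) is expected to be small or none beyond the scatter, with a real chance that this assay again reports only a limit for compound 4.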

Compound 4, half-maximal inhibitory concentration: > 20000 nM
Compound 4: only a limit was reported; the forecaster's own chance of this, stated with the estimate: 55%; middle value at least 1.3-fold (0.12 log units) from the limit.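

Compound 3 and compound 4 are both reported only as limits, so the change from thiophen-2-yl to furan-3-yl gives no readable step: the limit of > 20000 nM in this assay, at which 3 of the 4 values shown sit. On these data alone, what stays open is whether any group at this place on the core shared by compound 3 and compound 4 gives a measured value in this assay.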